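The source may hold more compounds than are shown below. What is called first, only, known or untested is meant among the compounds shown, and "the series" means these compounds.

In a functional assay on MT2 cells (Homo sapiens) for cytotoxicity, read by MTT assay (a higher number here means that more compound is tolerated, a lower number that less compound is tolerated), compound 1 (`CCc1ccc(Nc2nccs2)cc1OCC=C(C)C`) gives 31000 nM and compound 2 (`CCCc1ccc(Nc2nccs2)cc1OCC=C(C)C`) gives 23000 nM and the two stand within the scatter of each other. Compound 3 (`CC(C)=CCOc1cc(Nc2nccs2)ccc1C(C)C`) has the same atoms as compound 2, joined differently: isopropyl in place of propyl on an aromatic carbon and the rest of the structure stays unchanged. Among the measured compounds shown here, no compound with a branched chain at this place has been measured, so the data hold no direct precedent for the swap. For the measured compounds named here, the only measured step on this chain is a 1.3-fold lower number from compound 1 to compound 2 (0.13 log units; within the scatter) and on that basis no change beyond the scatter is expected in this assay in either direction. The expected step is a 1.1-fold higher number from compound 2 to compound 3 (0.04 log units; within the scatter) and it remains an estimate. The estimated value for compound 3 is 25000 nM (expected range 13000 nM to 45000 nM).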

Compound 3, half-maximal cytotoxic concentration: 31000 nM
Beside the measured number, compound 3's estimate is 1.2-fold (0.09 log units) below it; the measured number falls inside the stated range.
By their numbers in this assay, from the lowest: compounds 2, 1 and 3 (each within the scatter of the next).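

In this assay, among the compounds shown here, isopropyl on this aromatic carbon gives a 1.3-fold higher number from compound 2 to compound 3 (0.13 log units; within the scatter) and so supplies the first reading for a branched chain here: moving from propyl to its branched isomer leaves the number within the scatter. The added methyl on the chain carbon bound to the aromatic carbon gives no change at the digits printed from compound 1 to compound 3 (within the scatter) and so adds no separation from the ethyl chain of compound 1, leaving the ethyl, propyl and isopropyl chains of compounds 1, 2 and 3 all within the scatter of one another at this place. No evidence at hand accounts for this flat reading.

From the compounds shown here alone, whether it extends to a longer chain such as butyl, a tert-butyl group or a cyclopropyl ring remains open. So does the outcome with an amine or a carboxylic acid on this aromatic carbon.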